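Aryl halide swap on the cytotoxicity side of the series

The source may hold more compounds than are shown below. What is called first, only, known or untested is meant among the compounds shown, and "the series" means these compounds.

Measured compounds:
compound 1, `Fc1ccc(Nc2ccnc(NCCCNc3ccnc4cc(Cl)ccc34)n2)cc1`, 13700 nM
compound 2, `Clc1ccc(Nc2ccnc(NCCCNc3ccnc4cc(Cl)ccc34)n2)cc1`, 13400 nM
compound 3, `Fc1ccc(Nc2ccnc(NCCCCNc3ccnc4cc(Cl)ccc34)n2)cc1`, "not active" (no number reported)

In an ADME assay on Vero cells (Chlorocebus sabaeus) for cytotoxicity, read by neutral red uptake, with a stated time of 72 h (a higher number here means a weaker inhibitor, a lower number a stronger inhibitor), compound 1 gives 13700 nM and compound 2 gives 13400 nM. The step of a 1.0-fold lower number from compound 1 to compound 2 (0.01 log units; within the scatter) lies within the scatter; the change behind it is chloro in place of fluoro on an aromatic carbon. Compound 3 returned "not active" (no number reported) in this assay, so no single number stands for it. The difference between the core of compound 1 and the core of compound 3 is not broken down here.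

Compound 4, `Clc1ccc(Nc2ccnc(NCCCCNc3ccnc4cc(Cl)ccc34)n2)cc1`, is not yet measured. It differs from compound 3 by chloro in place of fluoro on an aromatic carbon, the same change as from compound 1 to compound 2, made at the same place. Because a 1.0-fold lower number from compound 1 to compound 2 (0.01 log units; within the scatter) was within the scatter, the step from compound 3 to compound 4 in this assay is expected to be small as well. With no number for compound 3, the expectation for compound 4 rests on compound 3 being recorded as not active, so compound 4 is estimated to be weak here and likely to return a limit rather than a number, with an estimate near 60000 nM, from 15000 nM to 250000 nM.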

Compound 4, half-maximal inhibitory concentration: 11000 nM
Compound 4: middle estimate off by 5.5-fold (0.74 log units), on the high side; measured number below the stated range.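

In this assay, within the data shown here, compound 3 carries no number while compound 4 gives 11000 nM as a measured value, so no step between the two can be read. Still open, from the compounds shown here alone, is whether chloro in place of fluoro on the core of compound 3 matches a 1.0-fold lower number from compound 1 to compound 2 (0.01 log units; within the scatter) in size. No measured evidence bears on this result.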